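The compounds below may be only part of what the source reports. "The series", "measured", "known", "first", "only" and "open" are said of these compounds alone.

Compound 1 `CC(=O)N1CCc2c(sc(NC(=O)c3ccc(Cl)cc3)c2C(N)=O)C1` and compound 2 `CN1CCc2c(sc(NC(=O)c3ccc(Cl)cc3)c2C(N)=O)C1` share one core. In an ADME assay on RAW264.7 cells (Mus musculus) for cytotoxicity, read by MTT assay, with a stated time of 48 h, tested at 50 uM (a lower number here means less inhibition, a higher number more inhibition at the concentration tested (going by the name of the read-out)), compound 1 gives 38.4%, while compound 2 gives 38.5%. The change between them, (methyl in place of acetyl on an amine nitrogen in a ring), makes a step of a number 0.1 percentage points higher from compound 1 to compound 2 (within the scatter). Compound 3 `CC(=O)N1CCc2c(sc(NC(=O)c3ccc(OCc4ccccc4)cc3)c2C(N)=O)C1` carries a different core, and the difference between the two cores is benzyloxy in place of chloro on an aromatic carbon; that change gives a number 26.8 percentage points lower from compound 1 to compound 3 (beyond the scatter), so that in this assay compound 3 gives 11.6%. Compound 4 `CN1CCc2c(sc(NC(=O)c3ccc(OCc4ccccc4)cc3)c2C(N)=O)C1` is not yet measured; it differs from compound 3 by methyl in place of acetyl on an amine nitrogen in a ring, the same change as from compound 1 to compound 2. Because the earlier step was a number 0.1 percentage points higher from compound 1 to compound 2 (within the scatter), the step from compound 3 to compound 4 is expected to be about a number 0.4 percentage points higher from compound 3 to compound 4 (within the scatter). Compound 4 is therefore estimated at 12%, between 2% and 25%.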

Compound 4, a percentage reported as inhibition, at one concentration (the size of the read-out at that concentration, not a potency): 37.6%
Compound 4: the middle estimate sits 25.6 percentage points below what was measured; measured number above the stated range.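

On the benzyloxy core, methyl in place of acetyl gives a number 26 percentage points higher from compound 3 to compound 4 (beyond the scatter) in this assay, so this change does not carry over unchanged from the chloro core: the same change on two cores in this assay, a number 0.1 percentage points higher (within the scatter) from compound 1 to compound 2 and a number 26 percentage points higher (beyond the scatter) from compound 3 to compound 4, 25.9 percentage points apart, beyond the scatter of two such steps
With methyl on the ring nitrogen, benzyloxy in place of chloro gives a number 0.9 percentage points lower from compound 2 to compound 4 (within the scatter), so that change also depends on the rest of the molecule: the same change on two cores in this assay, a number 26.8 percentage points lower (beyond the scatter) from compound 1 to compound 3 and a number 0.9 percentage points lower (within the scatter) from compound 2 to compound 4, 25.9 percentage points apart, beyond the scatter of two such steps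
This set of four compounds shows that neither step can simply be transferred from one core to the other, but it does not show why, or whether the same holds on any other core.

Going by these compounds, it remains open whether a longer chain on the ring nitrogen would behave like acetyl or like methyl. On these data alone, it also remains open how a methoxy group or an amine on the aromatic carbon would fit this picture.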